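The source may report more compounds than this note shows. Statements on the series, on what has been measured and on what is new or still open speak of the compounds shown alone.

Four compounds share a common theme: a hydrazone-bearing core joined through a triazole to a sugar-derived piece, with a para-substituted aromatic ring on the hydrazone side. Compound 1 has the structure `COc1ccc(N/N=C2\C(=O)N(Cc3cn(O[C@@H]4O[C@H](CC(C)=O)[C@H](OC(C)=O)[C@H](OC(C)=O)[C@H]4OC(C)=O)nn3)c3ccccc32)cc1` and compound 2 the structure `CC(=O)C[C@H]1O[C@@H](On2cc(CN3C(=O)/C(=N\Nc4ccc(C#N)cc4)c4ccccc43)nn2)[C@H](OC(C)=O)[C@@H](OC(C)=O)[C@H]1OC(C)=O`. Compound 3, with the structure `COc1ccc(N/N=C2\C(=O)N(Cc3cn(C[C@H]4O[C@@H]5OC(C)(C)O[C@@H]5[C@H]4O)nn3)c3ccccc32)cc1`, carries a different sugar-derived piece; how its core differs from the core of compound 1 is not broken down here. Compound 4, with the structure `CC1(C)O[C@H]2O[C@H](Cn3cc(CN4C(=O)/C(=N\Nc5ccc(C#N)cc5)c5ccccc54)nn3)[C@H](O)[C@H]2O1`, has not yet been measured.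

In an ADME assay on Vero cells (Chlorocebus sabaeus) for cytotoxicity, read by fluorescence and resazurin assay, with a stated time of 3 days (a higher number here means that more compound is tolerated, a lower number that less compound is tolerated), compound 1 gives 62500 nM. Compound 2 gives 75500 nM in this assay. The two differ in one place only, (cyano in place of methoxy on an aromatic carbon), and this change made a 1.2-fold higher number from compound 1 to compound 2 (0.08 log units; within the scatter). Compound 3 gives 74500 nM in this assay; its value and that of compound 2 lie within the usual scatter of each other, as do its value and that of compound 1.

From compound 3 to compound 4 the change is cyano in place of methoxy on an aromatic carbon, the same change that separates compound 1 from compound 2, in the same place. Among the compounds with values here, since that earlier change moved the number only within the scatter, compound 4 is expected to show a step of about a 1.1-fold higher number from compound 3 to compound 4 (0.06 log units; within the scatter) in this assay, because the step of a 1.2-fold higher number from compound 1 to compound 2 (0.08 log units; within the scatter) is the only guide for this change. Compound 4 is therefore estimated at 85000 nM in this assay, with a range from 45000 nM to 160000 nM.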

Compound 4, half-maximal cytotoxic concentration: 105000 nM
Beside the measured number, compound 4's estimate is 1.2-fold (0.09 log units) below it; the range from low to high includes it.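

In this assay, putting cyano in place of methoxy on the aromatic ring gives a 1.4-fold higher number from compound 3 to compound 4 (0.15 log units; within the scatter). Set beside the earlier case, this step shows that the change behaves alike on the two cores, with no sign that the core alters its outcome: the same change on two cores in this assay, a 1.2-fold higher number (0.08 log units; within the scatter) from compound 1 to compound 2 and a 1.4-fold higher number (0.15 log units; within the scatter) from compound 3 to compound 4, 1.2-fold (0.07 log units) apart, within the scatter of two such steps. It does not show that cyano is tolerated better than methoxy, since each step on its own stays within the usual scatter, and two cores are too few to predict what the same change would do on a third core or in a different kind of measurement.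

The compounds shown leave open what would happen with a group of another kind at this place on the ring, para to a large group, such as an amine, a carboxylic acid or a longer alkoxy chain in place of methoxy or cyano. They also leave open whether any change at this place could move the number beyond the scatter, since the only swap shown here, made twice, does not.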